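A few compounds are considered here, and "the series" means these few. Any claim that something is new, unique, unknown or untested is made for them only; others in the source may bear on it.

Compound 3 `CCCCN1CCC(CCC(=O)c2cc(Cl)c(N)cc2OCc2cc(OC)cc(OC)c2)CC1` stands highest of the three compounds in a functional assay for antagonist activity at 5-hydroxytryptamine receptor 4 (Rattus norvegicus) (a higher number here means a more potent compound, by a factor of ten per unit of this negative logarithm, a lower number a less potent compound), giving 8.9. Compound 1 `COc1cc(COc2cc(N)c(Cl)cc2C(=O)CCCCN2CCC(C)CC2)cc(OC)c1` gives 8.3 in this assay, and compound 2 `COc1cc(COc2cc(N)c(Cl)cc2C(=O)CCCCN2CCC(NC(N)=O)CC2)cc(OC)c1` gives 8.5 there, so that a number 0.60 log units higher from compound 1 to compound 3 (beyond the scatter) and a number 0.40 log units higher from compound 2 to compound 3 (beyond the scatter). Compound 4 `COc1cc(COc2cc(N)c(Cl)cc2C(=O)CCC2CCN(CCCNS(C)(=O)=O)CC2)cc(OC)c1` differs from compound 3 in one place: methanesulfonamido in place of methyl on a saturated chain carbon, three bonds along the chain from an amine nitrogen in a ring. For the measured compounds named here, no measured step alters exactly this group. The nearest comparison is the exchange of a methyl for a ureido group, which also brings a hydrogen-bond donor into the molecule, and that change gave a number 0.20 log units higher from compound 1 to compound 2 (within the scatter). The two remaining steps concern the link between the carbonyl and the ring amine, which compound 4 keeps unchanged from compound 3, so they give little guidance here. The expected step is therefore no change at the digits printed from compound 3 to compound 4 (within the scatter), not beyond the scatter. Compound 4 is estimated at 8.9 in this assay, within a range from 8.3 to 9.5.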

Compound 4, negative logarithm of the antagonist equilibrium constant: 8.8
For compound 4 the middle estimate is 0.10 log units above the measured one, within the range that was stated.
By their numbers in this assay, from the lowest: compounds 1, 2, 4 and 3 (each within the scatter of the next, the first and the last beyond it).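

Swapping the end methyl of the butyl chain for methanesulfonamido, on a saturated chain carbon, three bonds along the chain from an amine nitrogen in a ring, gives a number 0.10 log units lower from compound 3 to compound 4 (within the scatter) in this assay. The earlier compounds shown here left this end of the chain untouched, and this step shows that the butyl group of compound 3 can become 3-(methanesulfonamido)propyl, which adds a hydrogen-bond donor and hydrogen-bond acceptors, with no change beyond the scatter. Nothing given here accounts for this result. With a single such group at this position, no trend can be drawn for the chain end. Going by these compounds, whether a primary amine, a carboxylic acid or a longer chain carrying the methanesulfonamido group would fit equally well remains open.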